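The compounds below may be only part of what the source reports. "The series", "measured", "known", "first", "only" and "open" are said of these compounds alone.

Two closely related compounds have been measured in an assay on HEK293 cells for displacement of a labelled ligand from adenosine receptor A2b (Homo sapiens), read by scintillation counting; a lower number here means a stronger inhibitor, a higher number a weaker inhibitor. Compound 2, with the structure `CCn1c(=O)c2c(nc(Cc3ccco3)n2C)n(Cc2cccs2)c1=O`, gives 26.9 nM in this assay. Compound 1, with the structure `CCn1c(=O)c2c(nc(Cc3cccs3)n2C)n(Cc2cccs2)c1=O`, differs from it only in the ring that hangs from a saturated chain carbon bound to an aromatic carbon, thiophen-2-yl in compound 1 where compound 2 carries furan-2-yl, and compound 1 gives 35.5 nM. The step of a 1.3-fold lower number from compound 1 to compound 2 (0.12 log units; within the scatter) is within the scatter, so the two numbers cannot be told apart, and compound 2 has no neighbour that clearly differs from it.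

Compound 3, with the structure `CCn1c(=O)c2c(nc(Cc3c(F)cccc3F)n2C)n(Cc2cccs2)c1=O`, changes the same position again: 2,6-difluorophenyl in place of furan-2-yl on a saturated chain carbon bound to an aromatic carbon. Among the compounds with values here, the only measured step at this place, a 1.3-fold lower number from compound 1 to compound 2 (0.12 log units; within the scatter), swapped one five-membered ring for another without a change beyond the scatter. A six-membered ring bearing two fluorines is a larger change than that swap, so the precedent is thin; a modest step in either direction in this assay is plausible, and a change within the scatter is as likely as not. Compound 3 is therefore expected to give about 40 nM, with a range from 12 nM to 130 nM. That estimate means an expected step of a 1.5-fold higher number from compound 2 to compound 3 (0.17 log units; within the scatter).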

Compound 3, inhibition constant: 135 nM
Compound 3: the middle estimate sits 3.4-fold (0.53 log units) below what was measured, and the stated range ends below it.
By their numbers in this assay, from the lowest: compounds 2 and 1 (each within the scatter of the next); then compound 3.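

In this assay, the position on a saturated chain carbon bound to an aromatic carbon does not treat all rings alike: the change to 2,6-difluorophenyl gives a 5.0-fold higher number from compound 2 to compound 3 (0.70 log units; beyond the scatter) and a 3.8-fold higher number from compound 1 to compound 3 (0.58 log units; beyond the scatter), both beyond the scatter, whereas the earlier swap between furan-2-yl and thiophen-2-yl was not. Within the data shown here, the two five-membered rings therefore stay together, and 2,6-difluorophenyl is the first group here to move the number clearly, by a modest step toward a weaker inhibitor, which makes compound 3 the weakest of the three. Nothing available accounts for this shift.

This one change replaces a five-membered ring holding a hetero atom with a six-membered ring of carbon only and also brings in fluorine, so the compounds shown cannot separate these differences from one another. As far as these compounds go, it remains open whether a plain phenyl ring with no fluorine would sit with the five-membered rings or with compound 3, and how a pyridine ring or an amine would fare at this place.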